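The source may report more compounds than this note shows. Statements on the series, on what has been measured and on what is new or still open speak of the compounds shown alone.

Measured so far:
compound 1 `CCSC[C@@](O)([C@@H](Nc1cccc2nc(C)ccc12)c1ccc(OC)cc1)C(F)(F)F`, in a functional assay on THP-1 cells (Homo sapiens) (a lower number here means a smaller maximal response, a higher number a larger maximal response), compound 1 gives 86%
compound 2 `COc1ccc([C@H](Nc2cccc3nc(C)ccc23)[C@](O)(CSC)C(F)(F)F)c(Cl)c1F`, in this assay compound 2 gives 98%

Compound 2 stands highest of the two numbers; compound 1 is the nearest and lies lower, beyond the scatter. Compound 3 `COc1ccc([C@H](Nc2cccc3nc(C)ccc23)[C@](O)(CC#N)C(F)(F)F)c(Cl)c1F` has not been measured. It differs from compound 2 by cyano in place of methylsulfanyl on a saturated chain carbon, two bonds along the chain from an oxygen on a saturated carbon. Among the compounds with values here, no step of this kind has been measured. The step of a number 8 percentage points lower from compound 2 to compound 3 (within the scatter) is expected to be small, likely a slight decrease or none beyond the scatter. Compound 3 is estimated at 90%, with a range from 72% to 105%.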

Compound 3, largest response reached (Emax), in percent of the reference or control that the assay uses in the THP-1 assay: 83%
Beside the measured number, compound 3's estimate is 7 percentage points above it; measured number inside the range.
By their numbers in the THP-1 assay, from the lowest: compounds 3 and 1 (each within the scatter of the next); then compound 2.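

In the THP-1 assay, cyano in place of methylsulfanyl on this saturated chain carbon gives a number 15 percentage points lower from compound 2 to compound 3 (beyond the scatter), so the maximal response depends on the group held at this position. In a physicochemical assay for lipophilicity (on this read-out lower numbers stand for lower lipophilicity and higher numbers for higher lipophilicity), compound 2 gives 4.5 and compound 3 gives 3.4, so the same change also moves the partition coefficient.

A single pair cannot separate a link between the two read-outs from an effect specific to the nitrile. Going by these compounds, how an amine or a carboxylic acid on this carbon would fall on both read-outs remains open.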